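Adding a Bromine Where Three Analogues Show No Cytotoxicity

This account rests on a few compounds, and the source may have more. Where it says the series, first, only, none or still open, it means among the compounds named here.

Of the compounds shown here, three of this set have been tested in a functional assay on MCF7 cells (Homo sapiens) for cytotoxicity, read by sulforhodamine B assay, with a stated time of 48 h; a lower number here means that less compound is tolerated, a higher number that more compound is tolerated. Compound 1 `N#C/C(=C\C=C(/Cl)c1ccc(Br)cc1)C(=O)c1c[nH]c2ccccc12` gives > 100000 nM in this assay, which is a limit of the assay rather than a number. Compound 2 `COc1ccc(/C(Cl)=C/C=C(\C#N)C(=O)c2c[nH]c3ccccc23)cc1OC` gives > 100000 nM in this assay, again a limit. How the cores of compound 1 and compound 2 differ is not broken down here. Compound 3 `COc1ccc(/C(Cl)=C/C=C(\C#N)C(=O)c2c[nH]c3ccc(Br)cc23)cc1OC` gives > 100000 nM in this assay, also a limit.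

Compound 3 differs from compound 2 by bromo in place of hydrogen on an aromatic carbon. The step that the two limits leave unreadable from compound 2 to compound 3 cannot be sized because both values sit at the limit of > 100000 nM in this assay, at which 3 of the 3 values shown sit. All that can be said is that neither compound reached a measurable level of cytotoxicity within the tested range.

Compound 4 `N#C/C(=C\C=C(/Cl)c1ccc(Br)cc1)C(=O)c1c[nH]c2ccc(Br)cc12` has not yet been measured. It differs from compound 1 by bromo in place of hydrogen on an aromatic carbon, the same change at the same place that turns compound 2 into compound 3. Going by the values given here, with only one measured example of this change, and that one unreadable, there is no basis for predicting a shift in either direction. The step that the limit leaves unreadable from compound 1 to compound 4 is therefore expected to be negligible. Compound 4 is expected to give about 150000 nM, with a plausible range from 80000 nM to 400000 nM, and the assay would most likely once more report only a limit.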

Compound 4, concentration lethal to 50% of the cells: > 100000 nM
Compound 4: no number, only a limit; the forecaster's own chance of this, stated with the estimate: 85%; the middle value is on the limit's open side.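

No size can be read for the step from compound 1 to compound 4, because both results are limits of the assay rather than numbers, and all the compounds share the same one: the limit of > 100000 nM in this assay, at which 4 of the 4 values shown sit. The compounds shown leave open whether bromo in place of hydrogen on an aromatic carbon alters cytotoxicity at all, and which structures would give a measurable value.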